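Removing the Cyclopropyl from the Amide Nitrogen of Compound 3

This account rests on a few compounds, and the source may have more. Where it says the series, first, only, none or still open, it means among the compounds named here.

Of the compounds shown here, three of a shared core have been tested in a functional assay on the whole organism with Mus musculus as the target, at a dose of 100 mg/kg by the intraperitoneal route; a higher number here means more inhibition at the dose given (going by the name of the read-out), a lower number less inhibition. Compound 1 `NC(=O)/C=C1\CCc2cc(Cl)ccc21` gives 0% in this assay. Compound 2 `NC(=O)/C=C1\CCc2cc(F)cc(F)c21` gives 100% in this assay. Compound 3 `O=C(/C=C1\CCc2cc(F)ccc21)NC1CC1` gives 100% in this assay, level with compound 2 at the digits shown, and the two together stand highest of the three numbers, while compound 1 sits far below, beyond the scatter.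

The step under consideration goes from compound 3 to compound 4 `NC(=O)/C=C1\CCc2cc(F)ccc21`, which has not yet been measured in this assay. The change is hydrogen in place of cyclopropyl on an amide-type nitrogen. Compound 2, which also carries a hydrogen on that nitrogen, gives 100% in this assay, and compound 3, with the cyclopropyl, gives 100%; both lie at the top. Only compound 1, with its different halogen on the ring, falls to 0%.

The step from compound 3 to compound 4 is expected to be small, downward if anything, and likely within the scatter, as a number 15 percentage points lower from compound 3 to compound 4 (beyond the scatter). Compound 4 is therefore expected to give about 85% in this assay, with a range from 40% to 100%.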

Compound 4, a percentage reported as inhibition, in the whole organism at one dose (the size of the read-out at that dose, not a potency): 100%
Compound 4: the middle estimate sits 15 percentage points below what was measured; low and high end bracket the measured number.
By their numbers in this assay, from the lowest: compound 1; then compounds 2, 3 and 4 (each within the scatter of the next).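

In this assay, hydrogen and cyclopropyl on the amide-type nitrogen are not told apart at this dose: taking the cyclopropyl away leaves no change at the digits printed from compound 3 to compound 4 (within the scatter), so the ring is not needed for the read-out to stay at the top of the numbers measured. Going by these compounds alone, compound 4 also gives the core two single-place comparisons on the aromatic ring that the earlier compounds lacked: hydrogen in place of fluoro on an aromatic carbon gives no change at the digits printed from compound 2 to compound 4 (within the scatter), while fluoro in place of chloro on an aromatic carbon gives a number 100 percentage points higher from compound 1 to compound 4 (beyond the scatter), which ties the collapse seen with compound 1 to that one halogen exchange. No measurement at hand explains why this halogen exchange matters so much while the change on the nitrogen does not.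

Going by these compounds, it remains open whether a longer chain such as n-butyl, or a phenyl ring, on the amide-type nitrogen would keep the number, and whether a bromo or a methoxy in place of the fluoro would behave like fluoro or like chloro. On these data alone, since the read-out at one dose is a size and not a potency, it is also open whether compound 2, compound 3 and compound 4 would separate at a lower dose.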